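The source may hold more compounds than are shown below. What is called first, only, known or untested is meant among the compounds shown, and "the series" means these compounds.

Working notes on the series.

The shared core carries a substituent on a nitrogen on an aromatic ring; three variants have numbers in an assay on isolated protein for inhibition of Indoleamine 2,3-dioxygenase 1 (Homo sapiens), read by fluorescence, with a stated time of 60 min; a higher number here means a weaker inhibitor, a lower number a stronger inhibitor. Compound 1 `O=S1(=O)CC(Nc2nonc2/C(=N/O)Nc2ccc(F)c(Br)c2)C1` gives 99 nM. Compound 2 `N=S1(=O)CC(Nc2nonc2/C(=N/O)Nc2ccc(F)c(Br)c2)C1` gives 208 nM. Compound 3 `CN(C)S(=O)(=O)CCNc1nonc1/C(=N/O)Nc1ccc(F)c(Br)c1` gives 105 nM, the second highest of the three numbers; compound 3 sits within the scatter of both compound 1 and compound 2. The measured steps are a 2.1-fold higher number from compound 1 to compound 2 (0.32 log units; beyond the scatter), a 1.1-fold higher number from compound 1 to compound 3 (0.03 log units; within the scatter) and a 2.0-fold lower number from compound 2 to compound 3 (0.30 log units; within the scatter): only the ring-to-chain exchange at the aromatic nitrogen moves beyond the scatter, and only modestly.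

Compound 4 `O=S(=O)(CCNc1nonc1/C(=N/O)Nc1ccc(F)c(Br)c1)N1CCC1` differs from compound 3 by azetidin-1-yl in place of dimethylamino on a sulfonyl sulfur. Among the measured compounds shown here, no measured step touches the sulfonyl sulfur; the nearest comparison, from the cyclic sulfone of compound 1 to the open chain of compound 3, stayed within the scatter, so no step beyond the scatter is expected here. The number for compound 4 is estimated at 110 nM, with a range of 50 nM to 250 nM, an expected step of a 1.0-fold higher number from compound 3 to compound 4 (0.02 log units; within the scatter).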

Compound 4, half-maximal inhibitory concentration: 191 nM
Estimate against measurement, compound 4: 1.7-fold (0.24 log units) below; the range from low to high includes it.
By their numbers in this assay, from the lowest: compounds 1, 3, 4 and 2 (each within the scatter of the next, the first and the last beyond it).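

Among the compounds shown here, this is the first exchange made on the sulfonyl sulfur itself: azetidin-1-yl in place of dimethylamino gives a 1.8-fold higher number from compound 3 to compound 4 (0.26 log units; within the scatter), so closing the two carbons on the sulfonamide nitrogen into a four-membered ring does not separate the pair. Compound 4 also lies within the scatter of both cyclic compounds, with a 1.1-fold lower number from compound 2 to compound 4 (0.04 log units; within the scatter) and a 1.9-fold higher number from compound 1 to compound 4 (0.29 log units; within the scatter), so the side chain of compound 4 cannot be ranked against either ring, even though those two rings differ beyond the scatter. No supporting measurement bears on how this exchange reads.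

As far as these compounds go, whether a larger ring on the sulfonyl sulfur, such as piperidin-1-yl or morpholin-4-yl, would stay within the scatter remains open. So does the reading for an unsubstituted amino group there.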